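Moving the Chlorine Around the Phenyl Ring

A few compounds are considered here, and "the series" means these few. Any claim that something is new, unique, unknown or untested is made for them only; others in the source may bear on it.

Compound 1, `Cc1cc(NC(=O)Cn2cc(-c3ccc(Cl)cc3)nn2)no1`: 1910 nM
Compound 2, `Cc1cc(NC(=O)Cn2cc(-c3ccccc3Cl)nn2)no1`: > 30000 nM

In a functional assay on BMDM cells (Mus musculus, strain C57BL/6) for inhibition, with a stated time of 2 days (a lower number here means a stronger inhibitor, a higher number a weaker inhibitor), compound 1 gives 1910 nM. Compound 2 stands at the limit of > 30000 nM in this assay, at which 1 of the 2 values shown sits, so no number is known for it, only that limit. Within the data shown here, the single measured step, an at least 15-fold higher number from compound 1 to compound 2 (1.19 log units; beyond the scatter), is large. Compound 3, `Cc1cc(NC(=O)Cn2cc(-c3cccc(Cl)c3)nn2)no1`, differs from compound 2 by 3-chlorophenyl in place of 2-chlorophenyl on an aromatic carbon. With a 4-chlorophenyl the number was far lower, so a step back toward stronger inhibition is expected, of uncertain size given that compound 2 is known only as a limit; the expected step is an at least 3.7-fold lower number from compound 2 to compound 3 (0.57 log units; beyond the scatter). Compound 3 is therefore estimated at 8000 nM, between 2000 nM and 30000 nM.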

Compound 3, half-maximal inhibitory concentration: > 30000 nM
Compound 3: no number, only a limit; the forecaster's own chance of this, stated with the estimate: 35%; at least 3.7-fold (0.57 log units) between middle value and limit.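

With the 3-chlorophenyl, the result shows that the 2-chlorophenyl is not alone in losing the activity of compound 1, as the new compound brings an at least 15-fold higher number from compound 1 to compound 3 (1.19 log units; beyond the scatter). Of the three chlorophenyl compounds, only compound 1, with the 4-chlorophenyl, gives a number in this assay, and compound 3 gives only a limit: the limit of > 30000 nM in this assay, at which 2 of the 3 values shown sit. The step between compound 2 and compound 3 cannot be read, since both are limits.

From the compounds shown here alone, what a 4-aminophenyl or a 4-carboxyphenyl in place of the 4-chlorophenyl would give remains open.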